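The compounds below may be only part of what the source reports. "The series", "measured", "known", "first", "only" and "open" are said of these compounds alone.

In an ADME assay on L02 cells (Homo sapiens) for inhibition, read by CCK-8 assay, with a stated time of 48 h (a lower number here means a stronger inhibitor of growth, a higher number a weaker inhibitor of growth), compound 1 (`Cc1ccccc1Nc1nc(NCc2ccncc2)ncc1Cl`) gives > 100000 nM, which is a limit of the assay and not a number. Among the compounds with values here, compound 2 (`CN1CCN(c2ccc(Nc3ncc(Cl)c(NCc4ccc(C(F)(F)F)cc4)n3)nc2)CC1`) gives 26200 nM, the only actual number available so far, so it cannot yet be ranked against a second measured value. The next compound, compound 3 (`Cc1ccc(Nc2nc(Nc3ccc(N4CCN(C)CC4)cn3)ncc2Cl)cc1`), keeps the rest of compound 2 but carries 4-methylphenyl in place of 4-(trifluoromethyl)benzyl on a nitrogen on an aromatic ring. Within the data shown here, no measured pair of compounds differing in one place is available to show how large such a step might be in this assay. The expectation therefore starts from compound 2 and its 26200 nM, with a wide margin on either side. The expected change is no larger than the usual scatter, with no firm direction, and is estimated as a 1.1-fold higher number from compound 2 to compound 3 (0.06 log units; within the scatter). For compound 3 the estimated value is 30000 nM, with an expected range from 9000 nM to 90000 nM.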

Compound 3, concentration for 50% growth inhibition: 13900 nM
Estimate against measurement, compound 3: 2.2-fold (0.33 log units) above; low and high end bracket the measured number.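

In this assay, within the data shown here, putting 4-methylphenyl in place of 4-(trifluoromethyl)benzyl on a nitrogen on an aromatic ring gives the first step that can be read at this position: a 1.9-fold lower number from compound 2 to compound 3 (0.28 log units; within the scatter). The step stays within the scatter, even though the group goes from 11 heavy atoms, fluorine among them, to 7 heavy atoms of carbon alone, so this exchange shows no clear effect on the read-out. Compound 1 stands at a limit and not at a number, and it offers no comparison with this step: the limit of > 100000 nM in this assay, at which 1 of the 3 values shown sits.

Going by these compounds, a single step cannot separate the benzyl link from the trifluoromethyl and methyl groups, so the part each plays in this assay remains unknown. On these data alone, it also remains open whether a group of another kind on this nitrogen, such as a carboxylic acid, a primary amine or a longer alkyl chain, would move the number beyond the scatter, or whether the low sensitivity seen here holds only for groups built on a six-membered aromatic ring of carbon.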